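A few compounds are considered here, and "the series" means these few. Any claim that something is new, unique, unknown or untested is made for them only; others in the source may bear on it.

Compound 1 `O=S(=O)(CC1=NCCO1)C1=NNCC1c1ccccc1`: in a functional assay, tested at 100 ug/mL (a higher number here means a stronger effect of the compound at the concentration tested, a lower number a weaker effect), compound 1 gives "not active" (no number reported).
Compound 2 `Cc1ccc(C2CNN=C2S(=O)(=O)CC2=NCCO2)cc1`: in this assay compound 2 gives 46.8%.

Compound 1 therefore stands with no single number in this assay; it is reported only as inactive, while compound 2 carries a number. Within the data shown here, no computed step between compound 1 and compound 2 exists, so only their two readings can be set side by side. Compound 3 `O=S(=O)(CC1=NCCS1)C1=NNCC1c1ccccc1` differs from compound 1 in one place: a group of 5 heavy atoms (3 carbon, 1 nitrogen, 1 sulfur; one five-membered non-aromatic ring with 2 hetero atoms) in place of a group of 5 heavy atoms (3 carbon, 1 nitrogen, 1 oxygen; one five-membered non-aromatic ring with 2 hetero atoms), on a saturated chain carbon bound to a sulfonyl sulfur. Among the measured compounds shown here, no measured step of this kind is available, so the expected size rests on compound 1 alone. Because compound 1 gives "not active" (no number reported) in this assay, a small change in either direction, or none beyond the scatter, is expected. Compound 3 is accordingly estimated at 15% in this assay, with a range from 0% to 45%, and a sizeable chance that it too is reported only as inactive.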

Compound 3, a percentage reported as activity, at one concentration (the size of the read-out at that concentration, not a potency): "not active" (no number reported)
The entry for compound 3 holds no number; there is nothing to compare the estimate with.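

Among these compounds, compound 1 and compound 3 are both reported only as inactive in this assay, so no step between them can be read. The compounds shown leave open what this ring exchange does where a numerical reading exists, as for compound 2. No evidence bears on this result.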